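A few compounds are considered here, and "the series" means these few. Any claim that something is new, unique, unknown or untested is made for them only; others in the source may bear on it.

Compound 1, `CC(C)N(Cc1cccc(OCCCCCC(=O)O)c1)C(=O)c1ccccc1`, is assessed in an ADME assay on HEK293 cells (Homo sapiens) for cytotoxicity, read by CellTiter-Glo and resazurin assay, with a stated time of 72 h; on this read-out lower numbers stand for an effect already at smaller amounts and higher numbers for an effect only at larger amounts of compound. In this assay compound 1 gives only a limit, > 26000 nM, so no number is known for it. Two related compounds have been measured alongside it. Compound 2, `CC(C)N(Cc1cccc(OCCCCCC(=O)O)c1)C(=O)c1ccc(-c2ccoc2)cc1`, likewise reaches only the limit of > 26000 nM. Compound 3, `CC(C)N(Cc1cccc(OCCCCCC(=O)O)c1)C(=O)c1ccc(-c2cccc(OCc3ccccc3)c2)cc1`, also stops at the limit of > 26000 nM. Going by the values given here, the one step that can be traced, a step that the two limits leave unreadable from compound 1 to compound 2, is therefore unreadable in size, and all three compounds share the same limit, (the limit of > 26000 nM in this assay, at which 3 of the 3 values shown sit).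

The next compound, compound 4, `COc1cccc(-c2ccc(C(=O)N(Cc3cccc(OCCCCCC(=O)O)c3)C(C)C)cc2)c1`, differs from compound 1 by a single change: 3-methoxyphenyl in place of hydrogen on an aromatic carbon. Among the compounds with values here, no measured step bears readably on this change, since every value shown is a limit. The expectation for the step in this assay is therefore none beyond the scatter, with compound 4 most likely again reaching only the limit. Compound 4 is expected to give about 40000 nM, within roughly 20000 nM to 100000 nM. The expected step that the limit leaves unreadable from compound 1 to compound 4 would thus sit within the scatter.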

Compound 4, half-maximal effective concentration: > 20900 nM
Compound 4: a limit, no number; the forecaster's own chance of this, stated with the estimate: 85%; the middle value lies beyond the limit too.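

In this assay compound 4 gives only a limit and not a number, as do compound 1, compound 2 and compound 3, so no step among these four compounds can be read. The compounds shown leave open at what concentration, if any, each would become toxic to these cells.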